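Methoxy for cyano on the fused benzo ring of the series

The compounds below may be only part of what the source reports. "The series", "measured", "known", "first", "only" and "open" are said of these compounds alone.

In a functional assay on cells for positive allosteric modulation of metabotropic glutamate receptor 2 (Homo sapiens), read by fluorescence and calcium flux, with a stated time of 30 min (on this read-out lower numbers stand for an effect already at smaller amounts and higher numbers for an effect only at larger amounts of compound), compound 1 `Fc1cccc2c1nnn2CC1CC1` gives 1070 nM. Compound 2 `N#Cc1cccc2c1nnn2CC1CC1`, which carries a cyano in place of the fluoro, gives 620 nM in this assay. The one step so far, a 1.7-fold lower number from compound 1 to compound 2 (0.24 log units; within the scatter), stays within the scatter, so compound 2 and compound 1 lie within the scatter of each other and neither stands apart on the numbers shown. Compound 3 `COc1cccc2c1nnn2CC1CC1` is not yet measured. The change from compound 2 to compound 3 is methoxy in place of cyano on an aromatic carbon. Within the data shown here, only the fluoro-to-cyano step bears on this position, and it was within the scatter; no measured step shows what a methoxy at this place does, so there is nothing in the numbers to argue for a shift in either direction. For compound 3 a step of a 1.3-fold higher number from compound 2 to compound 3 (0.11 log units; within the scatter) is therefore expected in this assay, none beyond the scatter. Compound 3 is estimated at 800 nM in this assay, with a range from 300 nM to 2500 nM.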

Compound 3, half-maximal effective concentration: 400 nM
Compound 3: middle estimate off by 2.0-fold (0.30 log units), on the high side; low and high end bracket the measured number.
By their numbers in this assay, from the lowest: compounds 3, 2 and 1 (each within the scatter of the next, the first and the last beyond it).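

At this aromatic carbon, a 1.6-fold lower number from compound 2 to compound 3 (0.19 log units; within the scatter) in this assay does not separate methoxy from cyano, so the numbers give no ranking of these two groups. Among these compounds, the first step at this place to clear the scatter is the modest 2.7-fold lower number from compound 1 to compound 3 (0.43 log units; beyond the scatter), which shows that the number can respond to the group on this carbon, with methoxy on the lower side relative to fluoro, while cyano remains within the scatter of both. Nothing measured on these compounds accounts for the gap between methoxy and fluoro.

Still open, on these data alone, is whether an ethoxy group, an amine or a carboxylic acid on this same carbon would stay in the range of these three compounds or move clearly away from it, which would show how far the modest separation seen with methoxy can extend. Also open, as far as these compounds go, is whether the difference between methoxy and fluoro carries over when another part of the shared core changes, since all three compounds differ only at this one aromatic carbon.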